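Swapping Chloro for Fluoro on a Shared Core

This account rests on a few compounds, and the source may have more. Where it says the series, first, only, none or still open, it means among the compounds named here.

Compound 1, `O=C(CCC(=O)c1ccccc1)Nc1nc2ccc(Cl)cc2s1`, gives 300 mg/kg in a functional assay on the whole organism with Mus musculus as the target, in the maximal electroshock model, with a stated time of 4 h; a lower number here means that less compound is needed, a higher number that more compound is needed for the effect. Compound 2, `O=C(CCC(=O)c1ccccc1)Nc1nc2ccc(F)cc2s1`, differs from compound 1 by a single change, (fluoro in place of chloro on an aromatic carbon), and in this assay compound 2 gives 300 mg/kg. Between the two there is no change at the digits printed from compound 1 to compound 2 (within the scatter), so this swap left the result where it stood. Compound 3, `O=C(Nc1nc2ccc(Cl)cc2s1)c1ccccc1C(=O)c1ccccc1`, carries a different amide side on the shared core; how its core differs from that of compound 1 is not broken down here. In this assay compound 3 gives 100 mg/kg, the lowest of the three results, and its distance to compound 1 as well as to compound 2 lies beyond the usual scatter of this kind of measurement. Compound 4, `O=C(Nc1nc2ccc(F)cc2s1)c1ccccc1C(=O)c1ccccc1`, is not yet measured. It differs from compound 3 by fluoro in place of chloro on an aromatic carbon, the same change as that made from compound 1 to compound 2, at the same place. Because that earlier change gave no change at the digits printed from compound 1 to compound 2 (within the scatter), the step to compound 4 is expected to be no change at the digits printed from compound 3 to compound 4 (within the scatter). For compound 4 the estimate in this assay is therefore 100 mg/kg, expected to fall between 50 mg/kg and 200 mg/kg.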

Compound 4, minimum effective dose: 100 mg/kg
Estimate against measurement, compound 4: no gap at the digits printed, and the stated range covers the measured number.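

In this assay, the swap of chloro for fluoro on the core of compound 3 behaves as it did on the core of compound 1, with no change at the digits printed from compound 3 to compound 4 (within the scatter). Set side by side, the two steps agree: the same change on two cores in this assay, no change at the digits printed (within the scatter) from compound 1 to compound 2 and no change at the digits printed (within the scatter) from compound 3 to compound 4, 1.0-fold (0.00 log units) apart, within the scatter of two such steps. This shows that, on these two cores and in this one read-out, the swap carried over and left the result where it stood, but two pairs of compounds make no general rule, and the numbers do not explain why chloro and fluoro give matching results.

The compounds shown leave open whether a different group at the same place on the aromatic ring, such as a methoxy group, an amine or a carboxylic acid, would move the dose needed for the effect. Also open, going by these compounds, is whether the swap of chloro for fluoro would still leave the result unchanged on a core whose amide side carries a longer chain.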